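A smaller group on the sulfonyl sulfur of compound 3

The source may hold more compounds than are shown below. What is called first, only, known or untested is meant among the compounds shown, and "the series" means these compounds.

In an ADME assay (liver) for metabolic stability, with Liver microsome (Homo sapiens) as the target, read by LC-MS, using microsomes and NADPH, with a stated time of 5 min, at 37 degrees C (a higher number here means faster removal of the compound, a lower number slower removal), compound 3 `CCCn1ncc(S(=O)(=O)N[C@H](C)c2nc3ccc(C(F)(F)F)cc3n2CC)c1C` gives only a limit, > 100 mL.min-1.g-1. Compound 2 `CCCn1cc(S(=O)(=O)N[C@H](C)c2nc3ccc(C(F)(F)F)cc3n2CC)c(C)n1` also gives a limit, > 100 mL.min-1.g-1. Compound 4 `CCn1c([C@@H](C)NS(=O)(=O)c2cn(C)c(C)n2)nc2ccc(C(F)(F)F)cc21` carries 1,2-dimethyl-1H-imidazol-4-yl in place of the 5-methyl-1-propyl-1H-pyrazol-4-yl of compound 3, on a sulfonyl sulfur (1,2-dimethyl-1H-imidazol-4-yl in place of 5-methyl-1-propyl-1H-pyrazol-4-yl on a sulfonyl sulfur). For the measured compounds named here, two steps bear on this, both starting from compound 1 `CCn1c([C@@H](C)NS(=O)(=O)c2ccc(F)cc2)nc2ccc(C(F)(F)F)cc21`: an at least 3.8-fold higher number from compound 1 to compound 3 (0.58 log units; beyond the scatter) and an at least 3.8-fold higher number from compound 1 to compound 2 (0.58 log units; beyond the scatter). Each brought in a group with more heavy atoms than 4-fluorophenyl. The group entering here is smaller, so compound 4 is expected to move back toward compound 1 at 26 mL.min-1.g-1. The estimated change is downward, an at least 2.5-fold lower number from compound 3 to compound 4 (0.39 log units; beyond the scatter), and its size is loose since it starts from a limit. For compound 4 the estimate is 40 mL.min-1.g-1, with an expected range of 15 mL.min-1.g-1 to 100 mL.min-1.g-1.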

Compound 4, intrinsic clearance in microsomes: 43 mL.min-1.g-1
For compound 4 the middle estimate is 1.1-fold (0.03 log units) below the measured one; the range from low to high includes it.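

In this assay, a five-membered aromatic ring with 2 hetero atoms on the sulfonyl sulfur does not always give a limit reading: 1,2-dimethyl-1H-imidazol-4-yl gives an at least 2.3-fold lower number from compound 3 to compound 4 (0.36 log units; beyond the scatter) and an at least 2.3-fold lower number from compound 2 to compound 4 (0.36 log units; beyond the scatter). From the compounds shown here alone, both steps start from a limit, so their full size is unknown: the limit of > 100 mL.min-1.g-1 in this assay, at which 2 of the 4 values shown sit. This group also stays close to 4-fluorophenyl, with a 1.7-fold higher number from compound 1 to compound 4 (0.22 log units; within the scatter).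

Compound 3 and compound 4 differ in both ring and substituents, so the change cannot be assigned to either one. A 1,5-dimethyl-1H-pyrazol-4-yl group, replacing only the propyl chain with methyl, would separate them.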